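Nitrogen substituent swap on a urea-bearing benzimidazole thioether

The source may hold more compounds than are shown below. What is called first, only, known or untested is meant among the compounds shown, and "the series" means these compounds.

Of the compounds shown here, three have been tested in an assay on isolated protein for inhibition of Gonadotropin-releasing hormone receptor (Rattus norvegicus); a lower number here means a stronger inhibitor, a higher number a weaker inhibitor. Compound 1 `CC(C)n1c(SCc2ccccc2Cl)nc2cc(NC(=O)C3CC3)ccc21` reports only the assay limit, > 10000 nM, not a number. Compound 2 `COc1ccc(C(C)=O)cc1CSc1nc2cc(NC(=O)C3CC3)ccc2n1C(C)C` likewise reaches only the limit, > 10000 nM. Compound 3 `COc1ccc([N+](=O)[O-])cc1CSc1nc2cc(NC(=O)NC(C)(C)C)ccc2n1C1CC1` is the sole member with a measured value, 860 nM, so it stands alone among the numbers shown, with the other two values sitting at the limit of > 10000 nM in this assay, at which 2 of the 3 values shown sit. For the measured compounds named here, no pair of measured compounds differs in a single place, so no measured step is available from which to read the weight of any one change.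

Compound 4 `CCCn1c(SCc2cc([N+](=O)[O-])ccc2OC)nc2cc(NC(=O)NC(C)(C)C)ccc21` is the next compound to be tested in this assay. It differs from compound 3 by propyl in place of cyclopropyl on an aromatic nitrogen. Going by the values given here, with no measured single-point step in the set, and with compounds 1 and 2 giving only limits, the size of this step can only be guessed. The exchange keeps the count of heavy atoms and removes a ring, nothing more; the expectation is a step from compound 3 to compound 4 of a 1.4-fold higher number from compound 3 to compound 4 (0.14 log units; within the scatter), not beyond the usual scatter. Compound 4 is accordingly estimated at 1200 nM, within a range of 400 nM to 4000 nM.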

Compound 4, half-maximal inhibitory concentration: 120 nM
Beside the measured number, compound 4's estimate is 10-fold (1.00 log units) above it, and the stated range ends above it.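

For the compounds shown here, the aromatic nitrogen of the shared core proves sensitive to its substituent in this assay: propyl in place of cyclopropyl gives a 7.2-fold lower number from compound 3 to compound 4 (0.86 log units; beyond the scatter), the only step that can be read so far. The heavy-atom count stays the same across this exchange, and the three-membered ring is lost, so with the rest of compound 3 held constant, this position does not need a ring for the lower number. Compounds 1 and 2 differ from this pair in more than one place and offer no numerical comparison, and their values are limits, not numbers: the limit of > 10000 nM in this assay, at which 2 of the 4 values shown sit.

No measurement shown bears on why the step has this size.

Open, from the compounds shown here alone, is whether a longer chain such as butyl, or a propyl chain ending in an amine, on this nitrogen would extend the step or reverse it. Also open, going by these compounds, is whether propyl in place of cyclopropyl carries the same weight with the cyclopropyl amide of compounds 1 and 2 in place of the tert-butyl urea.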